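Adding a hydroxy group to compound 3

The compounds below may be only part of what the source reports. "The series", "measured", "known", "first", "only" and "open" are said of these compounds alone.

Measured so far in a functional assay on KB cells (Homo sapiens) for antiproliferative activity, read by MTT assay, with a stated time of 72 h (on this read-out higher numbers stand for weaker inhibition and lower numbers for stronger inhibition), are three compounds
compound 1 `COc1ccc(-c2ssc(=S)c2-c2cc(OC)c(OC)c(OC)c2)cc1O` gives 435 nM
compound 2 `COc1ccc(-c2ssc(=S)c2-c2cc(OC)c(OC)c(OC)c2)cc1N` gives 327 nM
compound 3 `COc1ccc(-c2ssc(=O)c2-c2cc(OC)c(OC)c(OC)c2)cc1` gives 324 nM

All three values lie within the usual scatter of one another, so compound 3 cannot be ranked against the other two. Compound 4 `COc1ccc(-c2ssc(=O)c2-c2cc(OC)c(OC)c(OC)c2)cc1O` is compound 3 with one change (hydroxy in place of hydrogen on an aromatic carbon): hydroxy in place of hydrogen on an aromatic carbon, ortho to a methoxy group.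

Within the data shown here, no measured step adds this hydroxy directly. Among the measured compounds shown here, the only measured step (a 1.3-fold lower number from compound 1 to compound 2 (0.12 log units; within the scatter)) replaces the hydroxy with amino, so it bears on the change only loosely and stays within the scatter. Compound 1 already carries the hydroxy on a related core, and its value (435 nM) lies within the scatter of that of compound 3 (324 nM). On that evidence, no step beyond the scatter is expected in this assay, and the expected change is small (a 1.1-fold lower number from compound 3 to compound 4 (0.05 log units; within the scatter)). Compound 4 is estimated at 290 nM (expected range 95 nM to 850 nM).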

Compound 4, half-maximal inhibitory concentration: 460 nM
Beside the measured number, compound 4's estimate is 1.6-fold (0.20 log units) below it; low and high end bracket the measured number.
By their numbers in this assay, from the lowest: compounds 3, 2, 1 and 4 (each within the scatter of the next).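

In this assay, the change from 4-methoxyphenyl to 3-hydroxy-4-methoxyphenyl can now be read directly on one core, as a step of a 1.4-fold higher number from compound 3 to compound 4 (0.15 log units; within the scatter). Hydroxy in place of hydrogen on this aromatic carbon, ortho to a methoxy group, therefore leaves the read-out within the scatter, whereas the earlier compounds offered no pair with and without this hydroxy. No measurement at hand helps to explain this result.

The compounds shown leave open how a fluorine, an ethoxy group or a carboxylic acid on this same carbon would read in this assay. They also leave open whether hydroxy in place of hydrogen would give a similar result on other aromatic carbons of this ring.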